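Swapping 3-nitrophenyl for 1-methylpiperidin-4-yl on the carbonyl carbon

The source may report more compounds than this note shows. Statements on the series, on what has been measured and on what is new or still open speak of the compounds shown alone.

In a functional assay on A549 cells (Homo sapiens) for antiproliferative activity, read by sulforhodamine B assay, with a stated time of 3 days (a higher number here means a weaker inhibitor of growth, a lower number a stronger inhibitor of growth), compound 1 `COc1ccc(NC(=O)c2cccc(Nc3ncc(F)c(Nc4ccc(F)cc4)n3)c2)cc1` gives 11000 nM, compound 2 `O=C(Nc1cccc(Nc2ncc(F)c(Nc3ccc(F)cc3)n2)c1)c1cnccn1` gives 10300 nM and compound 3 `O=C(Nc1cccc(Nc2ncc(F)c(Nc3ccc(F)cc3)n2)c1)c1cccc([N+](=O)[O-])c1` gives 7250 nM. Compound 3 lies within the scatter of both other compounds, so the three form a single level and cannot be ranked.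

Compound 4 `CN1CCC(C(=O)Nc2cccc(Nc3ncc(F)c(Nc4ccc(F)cc4)n3)c2)CC1` has 1-methylpiperidin-4-yl in place of 3-nitrophenyl on a carbonyl carbon.

Going by the values given here, two measured steps bear on this change. The closer one is a 1.4-fold lower number from compound 2 to compound 3 (0.15 log units; within the scatter), since it exchanges one aromatic group for another on the same carbonyl carbon. The other is a 1.1-fold lower number from compound 1 to compound 2 (0.03 log units; within the scatter). Both stay within the scatter, so this assay has so far shown little response to the changes made in this part of the series. Neither step, however, places a non-aromatic ring on that carbon, so compound 4 goes beyond what has been tested, and the data set no direction. The expected result is therefore no step beyond the scatter, with a wide margin on either side: a 1.1-fold higher number from compound 3 to compound 4 (0.04 log units; within the scatter).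

For compound 4 the estimated value is 8000 nM, with an expected range of 2500 nM to 25000 nM.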

Compound 4, concentration for 50% growth inhibition: 1330 nM
Beside the measured number, compound 4's estimate is 6.0-fold (0.78 log units) above it; the whole stated range lies above it.
By their numbers in this assay, from the lowest: compound 4; then compounds 3, 2 and 1 (each within the scatter of the next).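

In this assay, going by these compounds alone, this carbonyl carbon proves responsive after all: with 1-methylpiperidin-4-yl in place of 3-nitrophenyl there is a 5.5-fold lower number from compound 3 to compound 4 (0.74 log units; beyond the scatter) and with 1-methylpiperidin-4-yl in place of pyrazin-2-yl there is a 7.7-fold lower number from compound 2 to compound 4 (0.89 log units; beyond the scatter) while the aromatic exchange among the earlier compounds stayed within the scatter. Set against compound 1, where the amide also differs, ((1-methylpiperidin-4-yl)carbonyl)amino in place of (4-methoxyphenyl)carbamoyl gives an 8.3-fold lower number from compound 1 to compound 4 (0.92 log units; beyond the scatter) so compound 4 stands clear of all three others, and it is also the only one shown with a non-aromatic ring on that carbon. Nothing available here accounts for this step.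

Open still is whether the step follows the ring nitrogen with its methyl group or simply the loss of the aromatic ring, and a cyclohexyl group or an unsubstituted piperidin-4-yl on the same carbonyl carbon would separate these two readings. Also open, on these data alone, is whether an open-chain tertiary amine, such as a dimethylaminomethyl group, in that place would give a comparable number.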